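The compounds below may be only part of what the source reports. "The series", "measured", "known", "first", "only" and "open" are said of these compounds alone.

Three compounds share a core in which a pyrazole-linked scaffold carries a chloro-methoxyphenyl group, a pyridyl group and a phenyl ring bearing an amide or urea side arm. Compound 1 `COc1cc(-c2nn(-c3cccc(NC(=O)Nc4cc(C(F)(F)F)cc(C(F)(F)F)c4)c3)cc2-c2ccncc2)ccc1Cl` carries a urea to a bis(trifluoromethyl)phenyl group, compound 2 `COc1cc(-c2nn(-c3cccc(NC(=O)c4cccc(C(F)(F)F)c4)c3)cc2-c2ccncc2)ccc1Cl` a benzamide with a single trifluoromethyl group, and compound 3 `O=C(Nc1cccc(-n2cc(-c3ccncc3)c(-c3ccc(Cl)c(O)c3)n2)c1)Nc1ccc(Cl)c(Cl)c1` a urea to a dichlorophenyl group on a core that holds a hydroxyl instead of the methoxy group. In a functional assay on HT-29 cells (Homo sapiens) for inhibition, read by sulforhodamine B assay, with a stated time of 48 h (on this read-out higher numbers stand for weaker inhibition of growth and lower numbers for stronger inhibition of growth), compound 1 gives 702 nM, compound 2 gives 1390 nM and compound 3 gives 4890 nM. Compound 2 thus stands second highest of the three numbers: its value and that of compound 1 lie within the usual scatter of each other, while compound 3 sits beyond the scatter on the weaker side.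

Compound 4 `COc1cc(-c2nn(-c3cccc(NC(=O)c4ccc(Cl)c(C(F)(F)F)c4)c3)cc2-c2ccncc2)ccc1Cl` differs from compound 2 in one place: chloro in place of hydrogen on an aromatic carbon. Among the compounds with values here, no measured pair shows this particular change, so the expectation rests on the neighbouring values alone. Because compound 1 reaches 702 nM with a second substituent on the same arm, a small step toward stronger inhibition is expected, though it may not exceed the scatter. The step from compound 2 to compound 4 is estimated at a 1.6-fold lower number from compound 2 to compound 4 (0.21 log units; within the scatter). Compound 4 is therefore expected to give about 850 nM, most likely between 300 nM and 2500 nM.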

Compound 4, concentration for 50% growth inhibition: 3380 nM
For compound 4 the middle estimate is 4.0-fold (0.60 log units) below the measured one, and the stated range ends below it.
By their numbers in this assay, from the lowest: compounds 1 and 2 (each within the scatter of the next); then compounds 4 and 3 (each within the scatter of the next).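

Putting a chloro in place of hydrogen on the aromatic carbon ortho to the trifluoromethyl group of the benzamide arm gives, in this assay, a 2.4-fold higher number from compound 2 to compound 4 (0.39 log units; beyond the scatter). Within the data shown here, this is the only direct reading of a change at this position, and it shows that one added heavy atom here, para to a large group, weakens growth inhibition, so a further substituent on this arm is not in itself a gain. Nothing at hand explains why the step goes in this direction.

From the compounds shown here alone, whether this loss belongs to chloro in particular or to any added group stays open, and a fluoro, a methyl or an amine on the same carbon could separate those two readings. Going by these compounds, it is also open whether the same change would act alike on a urea arm, since compound 1 and compound 3 each differ from the amide compounds in more than one place and so cannot be set directly against them.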